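The source may hold more compounds than are shown below. What is called first, only, known or untested is meant among the compounds shown, and "the series" means these compounds.

Of the compounds shown here, three have so far been measured in a functional assay on MDA-MB-231 cells (Homo sapiens) for inhibition, read by MTT assay, with a stated time of 24 h; a lower number here means a stronger inhibitor, a higher number a weaker inhibitor. Compound 1 `CCCCCCCCn1cc(/C=[N+](\[O-])Cc2ccccc2)nn1` gives > 100000 nM, which is a limit of the assay and not a number. Compound 2 `[O-]/[N+](=C\c1cn(CCC(F)(F)C(F)(F)C(F)(F)C(F)(F)C(F)(F)C(F)(F)F)nn1)Cc1ccccc1` gives > 100000 nM, again only a limit. Compound 3 `CCCCCCCCn1cc(/C=[N+](\[O-])C(C)(C)C)nn1` gives 29700 nM.

Compound 3 arises from compound 1 by tert-butyl in place of benzyl on a double-bonded nitrogen and in this assay this gave an at least 3.3-fold lower number from compound 1 to compound 3 (0.52 log units; beyond the scatter). Compound 4 `CC(C)(C)/[N+]([O-])=C/c1cn(CCC(F)(F)C(F)(F)C(F)(F)C(F)(F)C(F)(F)C(F)(F)F)nn1` has not yet been measured in this assay. It arises from compound 2 by tert-butyl in place of benzyl on a double-bonded nitrogen, the same change, since the surroundings of the double-bonded nitrogen are the same in both pairs. How the core of compound 2 differs from the core of compound 1 is not broken down here.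

A step of similar size is expected on the second core, and the expected step is an at least 3.3-fold lower number from compound 2 to compound 4 (0.52 log units; beyond the scatter). This rests on the measured step of an at least 3.3-fold lower number from compound 1 to compound 3 (0.52 log units; beyond the scatter) and on compound 2 sitting at the limit of > 100000 nM in this assay, at which 2 of the 3 values shown sit, which leaves the true size of the step open. Compound 4 is accordingly expected to give about 30000 nM in this assay, within a range from 8000 nM to 100000 nM.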

Compound 4, half-maximal inhibitory concentration: 9800 nM
Beside the measured number, compound 4's estimate is 3.1-fold (0.49 log units) above it; low and high end bracket the measured number.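

In this assay, tert-butyl in place of benzyl on a double-bonded nitrogen lowers the number on the second core as well, with an at least 10-fold lower number from compound 2 to compound 4 (1.00 log units; beyond the scatter). The direction of the change therefore carries over between the two cores shown, and no compound here goes against it, but the two steps can be set side by side only as open-ended figures: the same change on two cores in this assay, an at least 3.3-fold lower number (0.52 log units; beyond the scatter) from compound 1 to compound 3 and an at least 10-fold lower number (1.00 log units; beyond the scatter) from compound 2 to compound 4; the limit leaves it open whether they differ. The data do not show that the change has a fixed size from one core to the other, and each step is only a lower bound, as both benzyl compounds give a limit of the assay and not a number: the limit of > 100000 nM in this assay, at which 2 of the 4 values shown sit.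

The compounds shown leave open whether the step would keep its direction with other groups in the same place, such as isopropyl or cyclohexyl. They also leave open whether it would hold on a core carrying an amine, a carboxylic acid or a longer chain.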